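The source may report more compounds than this note shows. Statements on the series, on what has been measured and on what is new or still open speak of the compounds shown alone.

Measured so far in an ADME assay on HeLa cells (Homo sapiens) for cytotoxicity, read by ATP content, with a stated time of 3 days; a lower number here means that less compound is tolerated, a higher number that more compound is tolerated:
- compound 1 `Cn1ccc(-n2c(=O)n(Cc3cc4cc(Cl)ccc4n3CCCC#N)c3cnccc32)n1`: > 50000 nM
- compound 2 `CS(=O)(=O)c1ccc(-n2c(=O)n(Cc3cc4cc(Cl)ccc4n3CCCC#N)c3cnccc32)cc1`: > 50000 nM
- compound 3 `N#CCCCn1c(Cn2c(=O)n(C3CC3)c3ccncc32)cc2cc(Cl)ccc21`: > 50000 nM

In this assay compound 1 gives > 50000 nM, which is a limit of the assay and not a number. Compound 2 gives > 50000 nM, likewise only a limit. Compound 3 gives > 50000 nM, again a limit, so compound 3 stands nowhere more precisely than that. The whole set sits at the limit of > 50000 nM in this assay, at which 3 of the 3 values shown sit. As a consequence the measured steps a step that the two limits leave unreadable from compound 1 to compound 2, a step that the two limits leave unreadable from compound 1 to compound 3 and a step that the two limits leave unreadable from compound 2 to compound 3 cannot be sized; each exchange at the aromatic nitrogen of the shared core left the value at the limit.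

Compound 4 `COc1ccc(-n2c(=O)n(Cc3cc4cc(Cl)ccc4n3CCCC#N)c3cnccc32)cc1` differs from compound 3 by 4-methoxyphenyl in place of cyclopropyl on an aromatic nitrogen. All three measured steps bear on it, since each exchanges a group at the same aromatic nitrogen, including two aryl groups, and none moved the read-out off the limit. The step from compound 3 to compound 4 is therefore expected as a step that the limit leaves unreadable from compound 3 to compound 4, with no readable change. Compound 4 is expected at 60000 nM, in the range 30000 nM to 150000 nM, most probably reported again only as a limit.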

Compound 4, half-maximal cytotoxic concentration: > 50000 nM
Compound 4: only a limit was reported; the forecaster's own chance of this, stated with the estimate: 85%; the middle value is on the limit's open side.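

In this assay compound 4 gives > 50000 nM, a limit and not a number, so the steps to compound 4 from compound 1, compound 2 and compound 3 cannot be read: the limit of > 50000 nM in this assay, at which 4 of the 4 values shown sit.

The compounds shown leave open at what concentration any of them becomes cytotoxic, and whether the group on the aromatic nitrogen changes that concentration.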